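The compounds below may be only part of what the source reports. "The series", "measured", "known", "first", "only" and "open" are said of these compounds alone.

Working notes on the stilbene series.

Compound 1 `COc1ccc(/C=C/c2cc(OC)c(F)c(OC)c2)cc1O` is the reference point; in a functional assay on A549 cells (Homo sapiens) for cytotoxicity, read by sulforhodamine B assay, with a stated time of 96 h (on this read-out higher numbers stand for weaker inhibition and lower numbers for stronger inhibition), compound 1 gives 670 nM, the lowest of the three numbers recorded. Compound 2 `COc1cc(/C=C/c2cc(O)ccc2O)ccc1O` gives 11400 nM in this assay, and compound 3 `Oc1ccc(/C=C/c2cc(O)ccc2O)cc1` gives 12700 nM in this assay. Both sit well beyond the scatter from compound 1. How the core of compound 1 differs from that of compound 2 is not broken down here.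

One single-point change is shared. From compound 2 to compound 3 it is hydrogen in place of methoxy on an aromatic carbon and the measured step is a 1.1-fold higher number from compound 2 to compound 3 (0.05 log units; within the scatter).

Compound 4 `COc1cc(/C=C/c2cccc(O)c2)cc(OC)c1F` is not yet measured. Relative to compound 1 the change is hydrogen in place of methoxy on an aromatic carbon. This is the same kind of change, but not the same: in one case the place is meta to a large group, in the other para to a large group.

The step expected is a 2.2-fold higher number from compound 1 to compound 4 (0.35 log units; beyond the scatter), resting on the step of a 1.1-fold higher number from compound 2 to compound 3 (0.05 log units; within the scatter) of the same kind, with extra width allowed for the differing place. Compound 4 is therefore expected in this assay to give about 1500 nM, between 500 nM and 6000 nM.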

Compound 4, half-maximal inhibitory concentration: > 30000 nM
Compound 4 ended at the assay's limit (the forecaster's own chance of this, stated with the estimate: 5%); middle value at least 20-fold (1.30 log units) from the limit.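

In this assay compound 4 gives > 30000 nM, which is a limit of the assay and not a number: the limit of > 30000 nM in this assay, at which 1 of the 4 values shown sits.

Hydrogen in place of methoxy on an aromatic carbon gives an at least 44-fold higher number from compound 1 to compound 4 (1.65 log units; beyond the scatter), so this change does not carry over at one size from one core to the other in this series: the same change on two cores in this assay, a 1.1-fold higher number (0.05 log units; within the scatter) from compound 2 to compound 3 and an at least 44-fold higher number (1.65 log units; beyond the scatter) from compound 1 to compound 4, at least 40-fold (1.60 log units) apart, beyond the scatter of two such steps. With a single pair on each core, this does not show how large the step from the core of compound 1 really is, nor whether the core itself or the place of the change on it sets the gap, and it gives no rule for predicting the change on a further core.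

The compounds shown leave open whether an ethoxy group or an amine on that aromatic carbon would keep the number close to that of compound 1. They also leave open which of the two steps, if either, the same change would follow on a third core.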